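Butyl for cyclohexyl on the aromatic nitrogen

A few compounds are considered here, and "the series" means these few. Any claim that something is new, unique, unknown or untested is made for them only; others in the source may bear on it.

In a functional assay on EOL1 cells (Homo sapiens) for inhibition, read by fluorescence, with a stated time of 72 h (a higher number here means a weaker inhibitor of growth, a lower number a stronger inhibitor of growth), compound 1 `CC(C)CCn1cnc2c(Nc3ccc(Cl)cc3)nc(N[C@H]3CC[C@H](N)CC3)nc21` gives 90 nM, compound 2 `N[C@H]1CC[C@H](Nc2nc(Nc3ccc(Cl)cc3)c3ncn(C4CCCCC4)c3n2)CC1` gives 140 nM and compound 3 `N[C@H]1CC[C@H](Nc2nc(Nc3ccc(O)cc3)c3ncn(C4CCCCC4)c3n2)CC1` gives 220 nM. Compound 2 holds the middle number of the three, within the scatter of both nearest values. Next comes compound 4 `CCCCn1cnc2c(Nc3ccc(Cl)cc3)nc(N[C@H]3CC[C@H](N)CC3)nc21`, with butyl in place of cyclohexyl on an aromatic nitrogen. The measured change at that place is a 1.6-fold higher number from compound 1 to compound 2 (0.19 log units; within the scatter), where cyclohexyl replaces isopentyl. The change on an aromatic carbon, a 1.6-fold higher number from compound 2 to compound 3 (0.20 log units; within the scatter), lies elsewhere and bears on this less directly. The expected size is a 1.4-fold lower number from compound 2 to compound 4 (0.15 log units; within the scatter), a step not expected to go beyond the scatter. For compound 4 the estimated value is 100 nM, with an expected range of 45 nM to 230 nM.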

Compound 4, concentration for 50% growth inhibition: 50 nM
For compound 4 the middle estimate is 2.0-fold (0.30 log units) above the measured one; low and high end bracket the measured number.
By their numbers in this assay, from the lowest: compounds 4, 1, 2 and 3 (each within the scatter of the next, the first and the last beyond it).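

In this assay, within the data shown here, the butyl chain on the aromatic nitrogen gives a 2.8-fold lower number from compound 2 to compound 4 (0.45 log units; beyond the scatter) and so provides the first step at this position that lies beyond the scatter. Set against the branched isopentyl chain, butyl gives a 1.8-fold lower number from compound 1 to compound 4 (0.26 log units; within the scatter) and the two chains cannot be told apart, so only cyclohexyl against butyl separates at this position. As far as these compounds go, whether a shorter propyl chain or a chain ending in an amine holds this level remains open. Nothing measured here accounts for the step.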